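Swapping the Pyridine Amide for an Aminoindazole

The compounds below may be only part of what the source reports. "The series", "measured", "known", "first", "only" and "open" are said of these compounds alone.

Of the compounds shown here, three sharing one core have been measured in a functional assay on K562/Adr cells (Homo sapiens) for inhibition, read by MTT assay, with a stated time of 48 h, tested at 30 uM; a lower number here means less inhibition, a higher number more inhibition at the concentration tested (going by the name of the read-out). Compound 1 `O=C(Nc1ccc(-c2cn([C@@H]3CN[C@H](C(=O)Nc4ccc(Cl)c(C(F)(F)F)c4)C3)nn2)cn1)C1CC1` gives 44.3%, the highest of the three numbers. Compound 2 `CC(C)(C)C(=O)Nc1ccc(-c2cn([C@@H]3CN[C@H](C(=O)Nc4ccc(Cl)c(C(F)(F)F)c4)C3)nn2)cn1` gives 19.1%, and compound 3 `CCN(CC)C(=O)c1cncc(-c2cn([C@@H]3CN[C@H](C(=O)Nc4ccc(Cl)c(C(F)(F)F)c4)C3)nn2)c1` gives 32.4%. Among the measured compounds shown here, the only step between two compounds that differ in a single place is a number 25.2 percentage points lower from compound 1 to compound 2 (beyond the scatter), which shows that the group sitting on the carbonyl carbon has a clear effect on the read-out.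

Compound 4 `Nc1n[nH]c2cc(-c3cn([C@@H]4CN[C@H](C(=O)Nc5ccc(Cl)c(C(F)(F)F)c5)C4)nn3)ccc12` has not yet been measured. It differs from compound 1 in one place: 3-amino-1H-indazol-6-yl in place of 6-((cyclopropylcarbonyl)amino)pyridin-3-yl on an aromatic carbon. For the measured compounds named here, no measured step exchanges the whole ring attached at that aromatic carbon, so the step from compound 1 to compound 2 bears on it only indirectly, by showing that this part of the molecule is sensitive to alteration. With the entire group replaced, the direction cannot be read from the data, and a wide range is appropriate. Compound 4 is expected to give 33%, between 8% and 60%, which corresponds to an expected step of a number 11.3 percentage points lower from compound 1 to compound 4 (beyond the scatter).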

Compound 4, a percentage reported as inhibition, at one concentration (the size of the read-out at that concentration, not a potency): 48.2%
Compound 4: middle estimate off by 15.2 percentage points, on the low side, and the stated range covers the measured number.
By their numbers in this assay, from the lowest: compound 2; then compound 3; then compounds 1 and 4 (each within the scatter of the next).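

In this assay the exchange of 6-((cyclopropylcarbonyl)amino)pyridin-3-yl for 3-amino-1H-indazol-6-yl amounts to a number 3.9 percentage points higher from compound 1 to compound 4 (within the scatter) and so leaves the read-out unchanged, although the whole group attached to the aromatic carbon is replaced. The earlier step of a number 25.2 percentage points lower from compound 1 to compound 2 (beyond the scatter) showed sensitivity to one small alteration on the carbonyl carbon, while compound 4 shows that this position can also carry a group with no carbonyl and no cyclopropyl ring and still match compound 1. Nothing measured here explains why these two different groups read alike.

As far as these compounds go, it remains open whether the amino group of 3-amino-1H-indazol-6-yl matters to this result. A hydroxyl group or a dimethylamino group in its place, or a plain phenyl ring in place of the whole group, would help to test that.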